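The source may report more compounds than this note shows. Statements on the series, on what has been measured and on what is new or still open speak of the compounds shown alone.

Measured compounds:
compound 1, `CCCCc1ccc(-c2cc(OC)cc(C(=O)Nc3nn[nH]n3)n2)cc1` — 61%
compound 2, `Cc1ccc(-c2cc(C)cc(C(=O)Nc3nn[nH]n3)n2)cc1` — 100%
compound 3, `CCCCc1ccc(-c2cc(C)cc(C(=O)Nc3nn[nH]n3)n2)cc1` — 67%

In a functional assay on the whole organism with Rattus norvegicus as the target, at a dose of 3 mg/kg by the oral route (a lower number here means a weaker effect, a higher number a stronger effect of the compound at the dose given), compound 3 and compound 1 lie within the scatter of each other, the step being a number 6 percentage points higher from compound 1 to compound 3 (within the scatter). Compound 2 sits above both beyond the scatter; its step to compound 3 is a number 33 percentage points lower from compound 2 to compound 3 (beyond the scatter), the one large movement in the series.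

Compound 4, `CCCCc1ccc(-c2cc(CC)cc(C(=O)Nc3nn[nH]n3)n2)cc1`, differs from compound 3 by methyl in place of hydrogen on a saturated chain carbon bound to an aromatic carbon. Among the compounds with values here, two measured steps bear on it. The step from compound 1 to compound 3 changes the same group on the core and moves nothing beyond the scatter, which suggests that this part of the structure is not sensitive to small changes. The step from compound 2 to compound 3 is a chain extension of a different substituent and lowers the number strongly, so growing a chain is not free of effect in this series, though that step concerns a different place. Weighing these, a small downward movement or no step beyond the scatter is expected for compound 4, with a number 7 percentage points lower from compound 3 to compound 4 (within the scatter) as the expected step. Compound 4 is therefore estimated at 60%, with a range from 40% to 80%.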

Compound 4, a percentage reported as inhibition, in the whole organism at one dose (the size of the read-out at that dose, not a potency): 70%
For compound 4 the middle estimate is 10 percentage points below the measured one; the range from low to high includes it.
By their numbers in this assay, from the lowest: compounds 1, 3 and 4 (each within the scatter of the next); then compound 2.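

In this assay, the methyl to ethyl change on a saturated chain carbon bound to an aromatic carbon gives a number 3 percentage points higher from compound 3 to compound 4 (within the scatter), and the exchange of methoxy for ethyl on an aromatic carbon gives a number 9 percentage points higher from compound 1 to compound 4 (within the scatter); methoxy, methyl and ethyl at this place on the shared core therefore all lie within the scatter of each other. The earlier compounds shown here showed this only for methoxy against methyl, so the series now holds a chain extension at this place that does not repeat the large movement at the other substituent, a number 33 percentage points lower from compound 2 to compound 3 (beyond the scatter). No supporting data accompany these values to account for this tolerance.

From the compounds shown here alone, it remains open whether this place stays as undemanding with a longer chain such as butyl, or with a different kind of group such as an amine or a carboxylic acid, and whether ethyl would give the same picture with the methyl of compound 2 on the other substituent. These are also read-outs at a single dose, so the values of compound 1, compound 3 and compound 4 leave any difference in potency among them unresolved.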